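The source may report more compounds than this note shows. Statements on the series, on what has been measured and on what is new or still open speak of the compounds shown alone.

Working notes on the series, all read in a functional assay, read by spectrophotometry, tested at 100 uM; on this read-out lower numbers stand for stronger inhibition and higher numbers for weaker inhibition. Compound 1 `O=C(/C=C/c1ccccc1)c1cccc(NC(=O)c2cc(-c3ccncc3)n[nH]2)c1` gives 71500 nM, compound 2 `O=C(/C=C/c1ccco1)c1cccc(NC(=O)c2cc(-c3ccncc3)n[nH]2)c1` gives 72300 nM, and compound 3 `O=C(/C=C/c1ccccc1Cl)c1cccc(NC(=O)c2cc(-c3ccncc3)n[nH]2)c1` gives 79800 nM. Compound 3 thus stands within the scatter of the other two, with a 1.1-fold higher number from compound 1 to compound 3 (0.05 log units; within the scatter) and a 1.1-fold higher number from compound 2 to compound 3 (0.04 log units; within the scatter).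

The next compound is compound 4 `CC(C)c1ccc(/C=C/C(=O)c2cccc(NC(=O)c3cc(-c4ccncc4)n[nH]3)c2)cc1`, which has 4-isopropylphenyl in place of 2-chlorophenyl on a double-bonded chain carbon bound to a double-bonded chain carbon.

All three measured steps bear on this change, since each alters the same group. Furan-2-yl in place of phenyl gave a 1.0-fold higher number from compound 1 to compound 2 (0.00 log units; within the scatter), and 2-chlorophenyl in place of furan-2-yl is the step already given for compound 3. None of these steps leaves the scatter. However, 4-isopropylphenyl appears in no measured compound, so this evidence covers only three groups.

On that basis, no step beyond the scatter is expected in this assay, and no direction can be assigned. The expected step is a 1.1-fold lower number from compound 3 to compound 4 (0.03 log units; within the scatter). For compound 4 the estimated value is 75000 nM, with an expected range of 45000 nM to 100000 nM.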

Compound 4, half-maximal inhibitory concentration: 60200 nM
Compound 4: the middle estimate sits 1.2-fold (0.10 log units) above what was measured; the range from low to high includes it.
By their numbers in this assay, from the lowest: compounds 4, 1, 2 and 3 (each within the scatter of the next).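

In this assay, the change at this position now extends to 4-isopropylphenyl, with 9 heavy atoms against 7 for 2-chlorophenyl, and the result still stays inside the scatter: a 1.3-fold lower number from compound 3 to compound 4 (0.12 log units; within the scatter), a 1.2-fold lower number from compound 2 to compound 4 (0.08 log units; within the scatter), and a 1.2-fold lower number from compound 1 to compound 4 (0.07 log units; within the scatter). For the compounds shown here, the set at this position now holds phenyl, furan-2-yl, 2-chlorophenyl and 4-isopropylphenyl, and no step among the four compounds leaves the scatter, so no group can be ranked above another. Nothing beyond these numbers is available to account for this flat picture.

Still open, as far as these compounds go, is whether a group such as a carboxylic acid or a dimethylamino substituent on the phenyl ring, or a longer chain in place of the 2-(4-isopropylphenyl)ethenyl group, would produce a step beyond the scatter. Also open, from the compounds shown here alone, is the separate contribution of substituent identity and ring location, as 2-chlorophenyl and 4-isopropylphenyl differ in both, and all four compounds share the same core, so these values say nothing about changes made to it.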